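A few compounds are considered here, and "the series" means these few. Any claim that something is new, unique, unknown or untested is made for them only; others in the source may bear on it.

Working notes on the series, aryl-piperazine variation.

Three compounds have been run in a functional assay on BGC-823 cells (Homo sapiens) for antiproliferative activity, read by MTT assay, with a stated time of 48 h; on this read-out lower numbers stand for stronger inhibition and higher numbers for weaker inhibition. Compound 1 `Fc1ccccc1N1CCN(Cn2nc(-c3ccc4c(c3)OCCO4)oc2=S)CC1` returns only a limit of the assay, > 50000 nM. Compound 2 `COc1ccc(N2CCN(Cn3nc(-c4ccc5c(c4)OCCO5)oc3=S)CC2)cc1` gives a readable number, 18900 nM. Compound 3 `COc1cccc(N2CCN(Cn3nc(-c4ccc5c(c4)OCCO5)oc3=S)CC2)c1` again sits at a limit of the assay, > 50000 nM. So compound 3 stands at the weak end of what has been seen: the step of an at least 2.6-fold higher number from compound 2 to compound 3 (0.42 log units; beyond the scatter) is the only one that reads against it, while a step that the two limits leave unreadable from compound 1 to compound 3, and the limit of > 50000 nM in this assay, at which 2 of the 3 values shown sit, covers both compound 1 and compound 3.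

Next is compound 4 `O=[N+]([O-])c1ccc(N2CCN(Cn3nc(-c4ccc5c(c4)OCCO5)oc3=S)CC2)cc1`, which differs from compound 3 as follows: 4-nitrophenyl in place of 3-methoxyphenyl on an amine nitrogen in a ring. Going by the values given here, the only readable number so far belongs to compound 2, whose 4-methoxyphenyl carries the same numbered substitution as the 4-nitrophenyl entering here, and an at least 2.6-fold lower number from compound 1 to compound 2 (0.42 log units; beyond the scatter) together with an at least 2.6-fold higher number from compound 2 to compound 3 (0.42 log units; beyond the scatter) marks that compound apart from the two at the limit. On that basis compound 4 is expected to move back toward a readable number, an estimated step of an at least 2.5-fold lower number from compound 3 to compound 4 (0.39 log units; beyond the scatter), with a fair chance that the assay again reports only a limit. For compound 4 the estimate is 20000 nM, within a range from 5000 nM to 60000 nM.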

Compound 4, half-maximal inhibitory concentration: > 50000 nM
Compound 4: a limit, no number (the forecaster's own chance of this, stated with the estimate: 40%); at least 2.5-fold (0.39 log units) between middle value and limit.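

In this assay, going by these compounds alone, nitro in place of methoxy on an aromatic carbon gives an at least 2.6-fold higher number from compound 2 to compound 4 (0.42 log units; beyond the scatter), the first step that changes the group while its numbered place on the phenyl stays the same. Among the compounds shown, a 4-substituted phenyl on the ring nitrogen is therefore not enough for a readable number, and the 4-methoxyphenyl remains the only group with one. Compound 4 returns a limit of the assay, not a number, and its steps to the other two compounds at a limit cannot be read: the limit of > 50000 nM in this assay, at which 3 of the 4 values shown sit.

No order can be given among compound 1, compound 3 and compound 4, since none of them has a number. As far as these compounds go, it remains open whether the readable value is particular to methoxy or would also appear with an amine, a hydroxyl or a longer alkoxy chain such as ethoxy on the same phenyl.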